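Triazolothiadiazine series: cyclopropyl to 2-fluorophenyl ketone

The compounds below may be only part of what the source reports. "The series", "measured", "known", "first", "only" and "open" are said of these compounds alone.

Measured so far in a functional assay on PC-3 cells (Homo sapiens) for cytotoxicity, read by MTT assay, with a stated time of 48 h; on this read-out higher numbers stand for weaker inhibition and lower numbers for stronger inhibition:
compound 1 `COc1cc(-c2nnc3n2NC(c2cccs2)C(C(=O)c2ccc(F)cc2)S3)cc(OC)c1OC` gives 27400 nM
compound 2 `COc1cc(-c2nnc3n2NC(c2ccco2)C(C(=O)C2CC2)S3)cc(OC)c1OC` gives 95200 nM
compound 3 `COc1ccc(C(=O)C2Sc3nnc(-c4cc(OC)c(OC)c(OC)c4)n3NC2c2cccs2)cc1` gives 95900 nM

Compound 2 stands second highest of the three numbers, within the scatter of compound 3 and a good way above compound 1. Compound 4 `COc1cc(-c2nnc3n2NC(c2ccco2)C(C(=O)c2ccccc2F)S3)cc(OC)c1OC` differs from compound 2 by 2-fluorophenyl in place of cyclopropyl on a carbonyl carbon. No measured step covers this change; the only step shown, a 3.5-fold higher number from compound 1 to compound 3 (0.54 log units; beyond the scatter), swaps substituents on an aryl ketone that compound 2 lacks, and gives no direct guide. The values of compounds 1 and 2 suggest an aryl ketone may lower the number, so a modest downward step a 2.4-fold lower number from compound 2 to compound 4 (0.38 log units; beyond the scatter) is expected in this assay. Compound 4 is estimated at 40000 nM, within 12000 nM to 130000 nM.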

Compound 4, half-maximal inhibitory concentration: > 100000 nM
Compound 4: only a limit was reported (the forecaster's own chance of this, stated with the estimate: 20%); at least 2.5-fold (0.39 log units) between middle value and limit.
By their numbers in this assay, from the lowest: compound 1; then compounds 2 and 3 (each within the scatter of the next). At a limit, above all of these: compound 4.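

In this assay compound 4 is reported only as a limit, > 100000 nM. With 2-fluorophenyl in place of cyclopropyl on the carbonyl carbon, the series shows an at least 1.0-fold higher number from compound 2 to compound 4 (0.02 log units; that floor lies within the scatter), so this first change at this position brings no lowering of the number. How far the number rises stays undefined, and the reading rests on a single value at the limit: the limit of > 100000 nM in this assay, at which 1 of the 4 values shown sits.

Still open, from the compounds shown here alone, is whether an amine or a longer alkyl chain on this carbonyl carbon would lower the number.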